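Two benzothiazolyl amines and a trifluoromethoxy analogue

A few compounds are considered here, and "the series" means these few. Any claim that something is new, unique, unknown or untested is made for them only; others in the source may bear on it.

Compound 1, `C#CCN(c1nc2ccc(F)cc2s1)c1nc2ccc(OC)cc2s1`: 24900 nM
Compound 2, `COc1ccc2nc(N(Cc3cc(-c4ccc(SC(F)(F)F)cc4)no3)c3nc4ccc(F)cc4s3)sc2c1`: 42900 nM

In a functional assay on U-937 cells (Homo sapiens) for antiproliferative activity, read by MTT assay (a lower number here means a stronger inhibitor, a higher number a weaker inhibitor), compound 2 gives 42900 nM, and in this assay compound 1 gives 24900 nM; the two numbers lie within the scatter of each other, so compound 2 is neither set apart from nor ranked against compound 1.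

Compound 3, `COc1ccc2nc(N(Cc3cc(-c4ccc(OC(F)(F)F)cc4)no3)c3nc4ccc(F)cc4s3)sc2c1`, is derived from compound 2 by the change (trifluoromethoxy in place of (trifluoromethyl)sulfanyl on an aromatic carbon). Among the compounds with values here, no measured pair shows this change, so a step of no more than the scatter, in either direction, is expected: a 1.1-fold lower number from compound 2 to compound 3 (0.03 log units; within the scatter). Compound 3 is therefore expected to give about 40000 nM, within 15000 nM to 110000 nM.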

Compound 3, half-maximal inhibitory concentration: 23100 nM
Beside the measured number, compound 3's estimate is 1.7-fold (0.24 log units) above it, and the stated range covers the measured number.
By their numbers in this assay, from the lowest: compounds 3, 1 and 2 (each within the scatter of the next).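

In this assay, trifluoromethoxy in place of (trifluoromethyl)sulfanyl on an aromatic carbon, para to a large group, gives a 1.9-fold lower number from compound 2 to compound 3 (0.27 log units; within the scatter). Within the data shown here, this is the first measured step at this position, and with oxygen in place of sulfur the two groups cannot be told apart here. No measurement on hand accounts for this result. The compounds shown leave open whether an amine, a carboxylic acid or a longer chain on this aromatic carbon would give a number beyond the scatter of compound 2 and compound 3.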